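A few compounds are considered here, and "the series" means these few. Any claim that something is new, unique, unknown or untested is made for them only; others in the source may bear on it.

Working notes on the series. Compound 1 `Nc1ncnn1/C(S)=N/C1CCCCC1` is the simpler member; in a functional assay on the whole organism for inhibition, with Rattus norvegicus as the target, at a dose of 30 mg/kg (a higher number here means more inhibition at the dose given (going by the name of the read-out), a lower number less inhibition), compound 1 gives 31%. Compound 2 `C/N=C(\S)n1nc(-c2ccc(C)cc2)nc1N` carries a methyl on a six-membered aromatic ring of carbon only, para to a large group; in this assay compound 2 gives 65%. On the two numbers shown compound 2 stands highest, and the gap between compound 2 and compound 1 lies beyond the usual scatter, so the inhibition of compound 2 in this assay is the higher of the pair. For the measured compounds named here, no single-point step between these two is available, as they differ in more than one place.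

Compound 3 `C/N=C(\S)n1nc(-c2ccc(F)cc2)nc1N` is the next member and has not yet been measured in this assay. It differs from compound 2 by fluoro in place of methyl on an aromatic carbon.

Going by the values given here, no measured step of this kind exists, so the expectation rests only on the value of compound 2 in this assay. The change is small in atom count, and the step from compound 2 to compound 3 in this assay is expected to be modest, a number 8 percentage points lower from compound 2 to compound 3 (within the scatter), not clearly beyond the scatter. For compound 3 the estimate in this assay is 57%, expected to fall between 38% and 76%.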

Compound 3, a percentage reported as inhibition, in the whole organism at one dose (the size of the read-out at that dose, not a potency): 73%
Compound 3: the middle estimate sits 16 percentage points below what was measured, and the stated range covers the measured number.
By their numbers in this assay, from the lowest: compound 1; then compounds 2 and 3 (each within the scatter of the next).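

For the compounds shown here, the step of a number 8 percentage points higher from compound 2 to compound 3 (within the scatter) is the first single-place reading in this assay, and it concerns one spot only: an aromatic carbon of the six-membered aromatic ring of carbon only, para to a large group. Fluoro in place of methyl at this spot leaves no difference that can be told from the scatter, so on these two compounds the inhibition at this dose stays in the same range with either group, which the earlier pair, differing in more than one place, could not show. Nothing measured here speaks to why the two groups read alike, and no supporting data bear on this result.

With only methyl and fluoro at this spot, the compounds shown do not tell whether a methoxy group, an amine, a carboxylic acid or a longer chain such as propyl would read alike there. They also leave open whether the likeness of compound 2 and compound 3 would hold at other doses, since a reading at one dose is not a potency.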